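Para Substituent Swap: Methyl to Fluoro on Compound 3

The source may hold more compounds than are shown below. What is called first, only, known or untested is meant among the compounds shown, and "the series" means these compounds.

Compound 1 `O=C1CSC(c2ccc(O)cc2)N1CCN1CCCCC1`: 76%
Compound 2 `O=C1CSC(c2ccc([N+](=O)[O-])cc2)N1CCN1CCCCC1`: 66%
Compound 3 `Cc1ccc(C2SCC(=O)N2CCN2CCCCC2)cc1`: 51%

In an ADME assay on Vero cells (Chlorocebus sabaeus) for cytotoxicity, read by neutral red uptake, tested at 394 ug/mL (on this read-out lower numbers stand for a stronger effect and higher numbers for a weaker effect at the one concentration tested), compound 3 stands lowest of the three measured numbers, with compound 2 nearest and compound 1 furthest, both beyond the scatter. Compound 4 `O=C1CSC(c2ccc(F)cc2)N1CCN1CCCCC1` differs from compound 3 by fluoro in place of methyl on an aromatic carbon. Within the data shown here, two measured steps bear on this change, both swaps of the group on the same aromatic carbon: a number 25 percentage points lower from compound 1 to compound 3 (beyond the scatter) and a number 15 percentage points lower from compound 2 to compound 3 (beyond the scatter). Each was modest, and each ended at compound 3. Among the measured compounds shown here, no fluoro compound has been measured, so nothing shows how far a fluoro group moves the number; the swaps seen so far gave only modest steps. Compound 4 is therefore expected to sit near compound 3, with an estimated step of a number 9 percentage points higher from compound 3 to compound 4 (within the scatter) and a wide range. Compound 4 is estimated at 60%, between 45% and 78%.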

Compound 4, a percentage reported as activity, at one concentration (the size of the read-out at that concentration, not a potency): 52%
Beside the measured number, compound 4's estimate is 8 percentage points above it; the range from low to high includes it.
By their numbers in this assay, from the lowest: compounds 3 and 4 (each within the scatter of the next); then compounds 2 and 1 (each within the scatter of the next).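

In this assay, fluoro and methyl on this aromatic carbon cannot be told apart (a number 1 percentage points higher from compound 3 to compound 4 (within the scatter)). Fluoro in place of nitro (a number 14 percentage points lower from compound 2 to compound 4 (beyond the scatter)) and in place of hydroxy (a number 24 percentage points lower from compound 1 to compound 4 (beyond the scatter)) both give steps beyond the scatter, so compound 4 joins compound 3 apart from compound 1 and compound 2. No measurement shown here accounts for this grouping.

On these data alone, whether an amine or a carboxylic acid on this carbon would fall with compound 3 and compound 4 or with compound 1 and compound 2 stays open. Also open, as far as these compounds go, is whether fluoro elsewhere on the aromatic ring would give the same number.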